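From Nitro to Amino at the Assay Limit

The compounds below may be only part of what the source reports. "The series", "measured", "known", "first", "only" and "open" are said of these compounds alone.

Measured in a functional assay on A549 cells (Homo sapiens) for antiproliferative activity, read by MTT assay, with a stated time of 48 h (on this read-out lower numbers stand for stronger inhibition and higher numbers for weaker inhibition), all three values being limits:
Compound 1 `COc1ccc(N2CCN(Cc3ccc4c(c3O)-c3ccc(cc3O)CCc3ccc(O)c(c3)Oc3ccc(cc3)CC4)CC2)cc1`: > 20000 nM
Compound 2 `CC(C)(C)OC(=O)N1CCN(Cc2ccc3c(c2O)-c2ccc(cc2O)CCc2ccc(O)c(c2)Oc2ccc(cc2)CC3)CC1`: > 20000 nM
Compound 3 `O=[N+]([O-])c1cc2cc(c1O)Oc1ccc(cc1)CCc1cccc(O)c1-c1ccc(cc1O)CC2`: > 20000 nM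

In this assay compound 3 gives no number, only the limit > 20000 nM. The whole series offers little more, since the data show (the limit of > 20000 nM in this assay, at which 3 of the 3 values shown sit).

Compound 4 `Nc1cc2cc(c1O)Oc1ccc(cc1)CCc1cccc(O)c1-c1ccc(cc1O)CC2` carries amino in place of nitro on an aromatic carbon, ortho to a hydroxy group: amino in place of nitro on an aromatic carbon.

Going by the values given here, the only measured step, a step that the two limits leave unreadable from compound 1 to compound 2, concerns a different substituent, and its size cannot be read. Among the compounds with values here, no measured step therefore sizes this exchange. With compound 3 at the limit > 20000 nM, only a move toward stronger inhibition could be read, so that is the expected direction, though compound 4 may well also return only a limit. The estimated change is an at least 1.3-fold lower number from compound 3 to compound 4 (0.12 log units; that floor lies within the scatter). For compound 4 the expected value is 15000 nM, with an estimated range from 5000 nM to 40000 nM.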

Compound 4, half-maximal inhibitory concentration: > 20000 nM
Compound 4: only a limit was reported; the forecaster's own chance of this, stated with the estimate: 45%; middle value at least 1.3-fold (0.12 log units) away from the limit.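

In this assay compound 3 and compound 4 both give only limits, so no step can be read for amino in place of nitro. The compounds shown leave open which change to the shared core, if any, would bring a value within the measurable range.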